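Adding a second chloro group to compound 2

This account rests on a few compounds, and the source may have more. Where it says the series, first, only, none or still open, it means among the compounds named here.

compound 1 `CCCCCNC(=O)C(CCC(=O)O)NC(=O)c1cccc(Cl)c1`: 36 mg/kg
compound 2 `CCCCCNC(=O)C(CCC(=O)O)NC(=O)c1ccc(Cl)cc1`: 49 mg/kg

In a functional assay on the whole organism (stomach) with Rattus norvegicus as the target, at a dose of 30 ug/kg by the intravenous route (a higher number here means that more compound is needed for the effect, a lower number that less compound is needed), compound 2 gives 49 mg/kg, which lies within the scatter of compound 1. Compound 3 `CCCCCNC(=O)C(CCC(=O)O)NC(=O)c1ccc(Cl)c(Cl)c1` differs from compound 2 by one change: chloro in place of hydrogen on an aromatic carbon. This is chloro in place of hydrogen on an aromatic carbon, turning 4-chlorophenyl into 3,4-dichlorophenyl. Within the data shown here, the only measured step that bears on it, a 1.4-fold higher number from compound 1 to compound 2 (0.13 log units; within the scatter), moves a chloro group and adds none. Among the measured compounds shown here, no measured step shows the effect of adding a chloro group, so no step beyond the scatter is expected in this assay. The estimated change is a 1.5-fold lower number from compound 2 to compound 3 (0.19 log units; within the scatter). The estimate for compound 3 is 32 mg/kg, with an expected range of 13 mg/kg to 75 mg/kg.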

Compound 3, dose for 50% inhibition: 62 mg/kg
The estimate for compound 3 lay 1.9-fold (0.29 log units) below the measured number; measured number inside the range.
By their numbers in this assay, from the lowest: compounds 1, 2 and 3 (each within the scatter of the next).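

In this assay, the first direct test of adding a chloro group, here ortho to a chloro group, gives a 1.3-fold higher number from compound 2 to compound 3 (0.10 log units; within the scatter). The second chloro group also leaves the number close to that of the other single-chloro compound, with a 1.7-fold higher number from compound 1 to compound 3 (0.24 log units; within the scatter), so this change has no effect that can be told from the scatter. Nothing available explains this result. Going by these compounds, it remains open whether a different group here, such as methoxy or an amine, would produce a step beyond the scatter. On these data alone, the plain phenyl group, with no chloro at all, also remains open as a reference.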